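The source may report more compounds than this note shows. Statements on the series, on what has been measured and on what is new or still open speak of the compounds shown alone.

Measured compounds
- compound 1 `CC(C1=C(CCN(C(C)C)C(C)C)Cc2ccccc21)c1ccccn1`: 2190 nM; 5130 nM; 11700 nM (3 entries)
- compound 2 `CC(C1=C(CN(C)C)Cc2ccccc21)c1ccccn1`: 87.1 nM

Going by the values given here, in an assay on CHO-K1 cells for binding affinity to muscarinic acetylcholine receptor M5 (Homo sapiens) (a higher number here means a weaker inhibitor, a lower number a stronger inhibitor), compound 2 gives 87.1 nM; this is the only number for compound 2, and one further entry for it did not yield a single number. Compound 1 in this assay gives 2190 nM; 5130 nM; 11700 nM (3 entries), and the repeat entries of compound 1 are spread widely, as the several entries of compound 1 in this assay, 2190 nM; 5130 nM; 11700 nM (3 entries) shows. Among the compounds with values here, compound 1 and compound 2 differ in more than one place, so no single step between them is counted; the two sets of numbers show only that compound 2 sits far lower than compound 1, well beyond the scatter.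

Compound 3 `CC(C1=C(CN(C)C(C)C)Cc2ccccc21)c1ccccn1` differs from compound 2 by isopropyl in place of methyl on an amine nitrogen. Within the data shown here, no measured pair isolates this change, so its size in this assay is unknown. The expectation is a step toward weaker binding, of moderate size, probably beyond the scatter but not approaching the numbers of compound 1. The estimate for compound 3 in this assay is 400 nM, with a range from 120 nM to 1500 nM. The step this implies, from compound 2 to compound 3, is expected to be a 4.6-fold higher number from compound 2 to compound 3 (0.66 log units; beyond the scatter).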

Compound 3, inhibition constant: 1120 nM
For compound 3 the middle estimate is 2.8-fold (0.45 log units) below the measured one; measured number inside the range.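

In this assay, going by these compounds alone, the step from methyl to isopropyl on this amine nitrogen is the first single change that can be read: a 13-fold higher number from compound 2 to compound 3 (1.11 log units; beyond the scatter). Compound 1 and compound 2 differ in more than one place, so their gap could not be assigned to any one change; this pair shows that replacing methyl with isopropyl at this nitrogen is enough on its own to produce a large step, with no ring, hydrogen-bond donor, hydrogen-bond acceptor or net charge entering or leaving. Nothing measured here gives a reason for the size of this step.

Still open, on these data alone, is how binding in this assay responds to intermediate or cyclic groups on this nitrogen, such as ethyl in place of methyl, or an azetidine or pyrrolidine ring containing the nitrogen. Also open is how much of the distance of compound 1 from compound 3 belongs to its longer chain and how much to its second isopropyl, since those two changes are not separated by any pair shown here.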